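A few compounds are considered here, and "the series" means these few. Any claim that something is new, unique, unknown or untested is made for them only; others in the source may bear on it.

Measured so far:
Compound 1, `CCCC1CCC(OC(=O)N[C@@H](CC(C)C)C(=O)N[C@H](C=O)C[C@@H]2CCNC2=O)CC1`: in a toxicity assay on Huh-7 cells (Homo sapiens) for cytotoxicity (a higher number here means that more compound is tolerated, a lower number that less compound is tolerated), compound 1 gives > 100000 nM, a limit of the assay.
Compound 2, `CC(C)C[C@H](NC(=O)OC1CCC(F)(F)CC1)C(=O)N[C@H](C=O)C[C@@H]1CCNC1=O`: in this assay compound 2 gives > 100000 nM, also a limit of the assay.

Both values sit at the same limit (the limit of > 100000 nM in this assay, at which 2 of the 2 values shown sit), so the step that the two limits leave unreadable from compound 1 to compound 2 cannot be read from them. Among the measured compounds shown here, compound 2 therefore stands at the limit of this assay, and the one further value shown is likewise a limit; no numbered cytotoxicity figure exists.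

The next compound, compound 3, `CC(C)C[C@H](NC(=O)OC1CCCCC1)C(=O)N[C@H](C=O)C[C@@H]1CCNC1=O`, differs from compound 2 by cyclohexyl in place of 4,4-difluorocyclohexyl on an oxygen next to a carbonyl group. For the measured compounds named here, the only measured step bears on the same oxygen, but its size is not readable, so nothing measured gives a scale for this change. Because compound 2 sits at > 100000 nM and the step that the two limits leave unreadable from compound 1 to compound 2 is unreadable, no shift beyond the scatter is expected. Compound 3 is estimated at 150000 nM, range 50000 nM to 500000 nM, an expected step that the limit leaves unreadable from compound 2 to compound 3, most probably again reported only as a limit.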

Compound 3, half-maximal cytotoxic concentration: > 100000 nM
Compound 3: only a limit was reported; the forecaster's own chance of this, stated with the estimate: 85%; the middle value lies beyond the limit too.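

In this assay compound 3 gives > 100000 nM, a limit of the assay, so no step among compound 1, compound 2 and compound 3 can be read: the limit of > 100000 nM in this assay, at which 3 of the 3 values shown sit.

The compounds shown leave open at what concentration any of them becomes cytotoxic, and whether these ring changes alter that concentration.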